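The compounds below may be only part of what the source reports. "The series", "measured", "known", "first", "only" and "open" are said of these compounds alone.

Among the compounds with values here, compound 1 `O=c1c(O)c(-c2ccccc2)oc2cc(OCc3ccccc3[N+](=O)[O-])cc(O)c12` is the only compound here with a definite number: in an ADME assay on Huh-5-2 cells (Homo sapiens) for cytotoxicity, read by WST assay, with a stated time of 3 days (a lower number here means that less compound is tolerated, a higher number that more compound is tolerated), compound 1 gives 32000 nM. Compound 2 `COc1cccc(COc2cc(O)c3c(=O)c(O)c(-c4ccccc4)oc3c2)c1` reaches only a limit of the assay, > 100000 nM. The step of an at least 3.1-fold higher number from compound 1 to compound 2 (0.49 log units; beyond the scatter) is therefore known only as a lower bound because the limit of > 100000 nM in this assay, at which 1 of the 2 values shown sits, caps what can be seen. Compound 3 `O=c1c(O)c(-c2ccccc2)oc2cc(OCc3ccc(Br)cc3)cc(O)c12` carries 4-bromophenyl in place of 2-nitrophenyl on a saturated chain carbon bound to an oxygen on an aromatic ring. Within the data shown here, the one measured step also swapped the 2-nitrophenyl for a different ring and raised the number, so a rise of similar or somewhat smaller size is expected, a 1.7-fold higher number from compound 1 to compound 3 (0.24 log units; within the scatter). Compound 3 is thus estimated at 55000 nM, between 20000 nM and 150000 nM.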

Compound 3, half-maximal cytotoxic concentration: > 100000 nM
Compound 3: no number, only a limit; the forecaster's own chance of this, stated with the estimate: 35%; at least 1.8-fold (0.25 log units) between middle value and limit.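

In this assay, a second replacement of the 2-nitrophenyl, this time by 4-bromophenyl, gives an at least 3.1-fold higher number from compound 1 to compound 3 (0.49 log units; beyond the scatter), so the rise at this place no longer rests on a single ring. That step is again only a lower bound, and the step between compound 2 and compound 3 cannot be read, because both sit at the limit of the assay: the limit of > 100000 nM in this assay, at which 2 of the 3 values shown sit.

From the compounds shown here alone, only compound 1 has a definite number, so how far the other two rings differ from each other stays open. Also open, going by these compounds, is whether a ring carrying an amine or a carboxylic acid at this place would give a number within range.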